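This account rests on a few compounds, and the source may have more. Where it says the series, first, only, none or still open, it means among the compounds named here.

Measured so far in an ADME assay on microsomes from liver (Rattus norvegicus) for metabolic stability; on this read-out higher numbers stand for a longer-lived compound and lower numbers for a shorter-lived compound:
- compound 1 `CCC(CC)C(/C=C1\OC(=O)NC1=O)c1ccc(-c2ccc3cccc(F)c3c2)[nH]c1=O`: > 3 h
- compound 2 `CC(C)/C(=C1/SC(=O)NC1=O)c1ccc(-c2ccc3cccc(F)c3c2)[nH]c1=O`: > 3 h
- compound 3 `CC(C)[C@@H](c1ccc(-c2ccc3cccc(F)c3c2)[nH]c1=O)[C@H]1OC(=O)NC1=O`: 1.93 h

Compound 1 stands at > 3 h, which is a limit and not a number. Compound 2 stands at > 3 h, also a limit. Only compound 3 gives a number, 1.93 h.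

Compound 4 `O=C1NC(=O)/C(=C/C(c2ccc(-c3ccc4cccc(F)c4c3)[nH]c2=O)C2CCCC2)O1` has cyclopentyl in place of pentan-3-yl on a saturated chain carbon bound to an aromatic carbon and a double-bonded chain carbon. Going by the values given here, no measured pair sizes this change, so no step beyond the scatter is expected in this assay, in either direction. The expected step is a number no higher from compound 1 to compound 4 (the limit leaves the size open). The estimate for compound 4 is 3 h, with an expected range of 1.5 h to 6 h.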

Compound 4, half-life: > 3 h
Compound 4: a limit, no number (the forecaster's own chance of this, stated with the estimate: 55%); the middle value lies on the limit itself.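

In this assay compound 1 and compound 4 both end at a limit and not a number, so no step can be read for cyclopentyl in place of pentan-3-yl: the limit of > 3 h in this assay, at which 3 of the 4 values shown sit. The compounds shown leave open how far beyond that limit either compound lies, and whether the two differ at all.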